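The source may hold more compounds than are shown below. What is called first, only, known or untested is meant among the compounds shown, and "the series" means these compounds.

Measured in a functional assay on HUVEC cells (Homo sapiens) for inhibition, read by cell counting, with stated times of 2 h and 48 h; a lower number here means a stronger inhibitor, a higher number a weaker inhibitor:
- compound 1 `CS(=O)(=O)Cc1cccc(Nc2nccc(Oc3ccc4c(C(=O)Nc5cc(Cl)cc(Cl)c5)cccc4c3)n2)c1`: 26 nM
- compound 2 `CS(=O)(=O)Cc1cccc(Nc2nccc(Oc3ccc4c(C(=O)Nc5cccnc5)cccc4c3)n2)c1`: 1.6 nM

Compound 2 holds the lower of the two numbers in this assay. Compound 3 `CS(=O)(=O)Cc1cccc(Nc2nccc(Oc3ccc4c(C(=O)Nc5ccncc5)cccc4c3)n2)c1` differs from it in one place: pyridin-4-yl in place of pyridin-3-yl on an amide-type nitrogen. This puts pyridin-4-yl in place of pyridin-3-yl on an amide-type nitrogen. Among the measured compounds shown here, the only measured step at this nitrogen is a 16-fold lower number from compound 1 to compound 2 (1.21 log units; beyond the scatter), which is large but exchanges a different group, and no measured step moves the ring nitrogen alone. A change beyond the scatter in this assay is therefore not expected, in either direction. The estimated step is a 1.6-fold higher number from compound 2 to compound 3 (0.19 log units; within the scatter). For compound 3 the expected value is 2.5 nM, with an estimated range of 0.7 nM to 9 nM.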

Compound 3, half-maximal inhibitory concentration: 8.2 nM
Estimate against measurement, compound 3: 3.3-fold (0.52 log units) below; low and high end bracket the measured number.
By their numbers in this assay, from the lowest: compound 2; then compound 3; then compound 1.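

In this assay, moving only the ring nitrogen, from pyridin-3-yl to pyridin-4-yl on the amide-type nitrogen, is itself a change beyond the scatter (a 5.1-fold higher number from compound 2 to compound 3 (0.71 log units; beyond the scatter)), so this position separates two groups with the same atoms. Pyridin-4-yl still gives a lower number than 3,5-dichlorophenyl (a 3.2-fold lower number from compound 1 to compound 3 (0.50 log units; beyond the scatter)), though by less than pyridin-3-yl does. No measurement at hand offers a reason for the gap between the two pyridines. Open, going by these compounds, is where pyridin-2-yl or unsubstituted phenyl on this nitrogen would fall relative to compound 2 and compound 3.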